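The source may hold more compounds than are shown below. What is called first, only, known or untested is meant among the compounds shown, and "the series" means these compounds.

Within the data shown here, in an ADME assay on L02 cells (Homo sapiens) for cytotoxicity, read by MTT assay, with a stated time of 48 h (on this read-out lower numbers stand for stronger inhibition and higher numbers for weaker inhibition), compound 3 `CCn1c(C(=O)NCC(OC)OC)ccc1C(CC)(CC)c1ccc(OCC(O)C(C)(C)C)c(C)c1` gives 22200 nM, the highest of the three numbers so far. Compound 2 `CCOC(=O)CN(C)C(=O)c1ccc(C(CC)(CC)c2ccc(OCC(O)C(C)(C)C)c(C)c2)n1CC` gives 10100 nM, and compound 1 `CCn1c(C(=O)NCCN)ccc1C(CC)(CC)c1ccc(OCC(=O)C(C)(C)C)c(C)c1` gives 2500 nM. Compound 4 `CCn1c(C(=O)NCCN)ccc1C(CC)(CC)c1ccc(OCC(O)C(C)(C)C)c(C)c1` alters only the side chain of compound 3, with aminomethyl in place of dimethoxymethyl on a saturated chain carbon bound to an amide-type nitrogen. Among the measured compounds shown here, the only measured step at this amide, a 2.2-fold higher number from compound 2 to compound 3 (0.34 log units; beyond the scatter), was modest. Compound 1 already bears the 2-aminoethyl chain and sits at 2500 nM, but it differs elsewhere in the molecule, so it is only a rough guide. The expected change is a moderate one towards a lower number, a 3.7-fold lower number from compound 3 to compound 4 (0.57 log units; beyond the scatter). Compound 4 is estimated at 6000 nM, within an expected range of 2300 nM to 15000 nM.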

Compound 4, half-maximal inhibitory concentration: 2400 nM
The estimate for compound 4 lay 2.5-fold (0.40 log units) above the measured number; measured number inside the range.
By their numbers in this assay, from the lowest: compounds 4 and 1 (each within the scatter of the next); then compound 2; then compound 3.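

In this assay, the 2-aminoethyl chain gives a larger step at this amide than the one seen earlier (a 9.3-fold lower number from compound 3 to compound 4 (0.97 log units; beyond the scatter)), and it also stands clear of compound 2 (a 4.2-fold lower number from compound 2 to compound 4 (0.62 log units; beyond the scatter)). At the other end of the molecule, 1-hydroxy-2,2-dimethylpropyl in place of (tert-butyl)carbonyl does not separate the two compounds (a 1.0-fold lower number from compound 1 to compound 4 (0.02 log units; within the scatter)). No available evidence explains these steps.

Still open, on these data alone, is how much depends on the chain's terminal amine and how much on its length. A dimethylamino group at the chain end or a longer 3-aminopropyl chain would test this.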